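The source may report more compounds than this note shows. Statements on the series, on what has been measured and on what is new or still open speak of the compounds shown alone.

Measured so far in an assay on U2OS cells for activation of nuclear factor erythroid 2-related factor 2 (Homo sapiens), read by beta-arrestin recruitment, with a stated time of 6 h; on this read-out lower numbers stand for an effect already at smaller amounts and higher numbers for an effect only at larger amounts of compound:
compound 1, `O=S(=O)(/C=C\c1ncccc1F)c1ccccc1F`, gives 482 nM
compound 2, `O=S(=O)(/C=C\c1ncccc1Cl)c1ccccc1F`, gives 1030 nM
compound 3, `O=S(=O)(/C=C/c1cccnc1)c1ccccc1F`, gives 6860 nM

Between compound 1 and compound 2 the only change is chloro in place of fluoro on an aromatic carbon, and it brought a 2.1-fold higher number from compound 1 to compound 2 (0.33 log units; beyond the scatter). Compound 3 stands highest of the three; how its core differs from the core of compound 1 is not broken down here. Compound 4, `O=S(=O)(/C=C/c1cccnc1)c1ccccc1Cl`, differs from compound 3 by chloro in place of fluoro on an aromatic carbon. This is the same kind of change as from compound 1 to compound 2, but the surroundings differ: there the ring carried 1 nitrogen and the site lay two atoms from the ring nitrogen, here the ring is of carbon only. Resting on the modest step seen from compound 1 to compound 2, the expected step is a 1.9-fold higher number from compound 3 to compound 4 (0.28 log units; within the scatter). Compound 4 is therefore estimated at 13000 nM, between 5000 nM and 32000 nM.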

Compound 4, half-maximal effective concentration: 2850 nM
For compound 4 the middle estimate is 4.6-fold (0.66 log units) above the measured one; measured number below the stated range.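

In this assay, chloro in place of fluoro on an aromatic carbon brought a 2.4-fold lower number from compound 3 to compound 4 (0.38 log units; beyond the scatter), so the direction of the earlier step did not carry over to this core. Set side by side, the two cases read: the same change on two cores in this assay, a 2.1-fold higher number (0.33 log units; beyond the scatter) from compound 1 to compound 2 and a 2.4-fold lower number (0.38 log units; beyond the scatter) from compound 3 to compound 4, 5.1-fold (0.71 log units) apart, beyond the scatter of two such steps. This shows that the change cannot be carried between these cores as a fixed step, but two pairs do not show which difference between the cores goes with the reversal, or how the change would behave on a further core.

The compounds shown leave open how bromo, methyl or methoxy would read at this aromatic carbon. They also leave open whether the step would repeat on a core bearing an amine or a carboxylic acid.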